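This account rests on a few compounds, and the source may have more. Where it says the series, first, only, none or still open, it means among the compounds named here.

In a functional assay on MGC-803 cells (Homo sapiens) for antiproliferative activity, read by CCK-8 assay, with a stated time of 72 h, tested at 8 uM (a lower number here means a weaker effect, a higher number a stronger effect of the compound at the concentration tested), compound 1 `Nc1ccccc1NC(=O)c1ccc(CSC(=S)N2CCN(c3ccc(Cl)cc3)CC2)cc1` gives 17.2%, compound 2 `CC1CCCCN1C(=S)SCc1ccc(C(=O)Nc2ccccc2N)cc1` gives 86.9% and compound 3 `CCN(Cc1ccncc1)C(=S)SCc1ccc(C(=O)Nc2ccccc2N)cc1` gives 85.2%. Compound 3 thus stands second highest of the three numbers: its nearest neighbour is compound 2, within the scatter, and its furthest is compound 1, beyond the scatter. Within the data shown here, the single measured step at the thiocarbonyl carbon, a number 1.7 percentage points lower from compound 2 to compound 3 (within the scatter), shows that exchanging the amino substituent there left the read-out essentially unchanged. Compound 4 `CC1CCN(C(=S)SCc2ccc(C(=O)Nc3ccccc3N)cc2)CC1` differs from compound 3 by 4-methylpiperidin-1-yl in place of ethyl((pyridin-4-yl)methyl)amino on a thiocarbonyl carbon, so it carries a methylpiperidinyl ring of the same kind as compound 2, which gave 86.9%. On that basis no step beyond the scatter is expected in this assay, the estimated change being a number 0.8 percentage points higher from compound 3 to compound 4 (within the scatter). For compound 4 the expected value is 86%, with a range from 72% to 95%.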

Compound 4, a percentage reported as inhibition, at one concentration (the size of the read-out at that concentration, not a potency): 81.9%
Compound 4: middle estimate off by 4.1 percentage points, on the high side; the range from low to high includes it.
By their numbers in this assay, from the lowest: compound 1; then compounds 4, 3 and 2 (each within the scatter of the next).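

In this assay, exchanging the ring position of the methyl group, 4-methylpiperidin-1-yl in place of 2-methylpiperidin-1-yl on the thiocarbonyl carbon, gives a number 5 percentage points lower from compound 2 to compound 4 (within the scatter). Losing the pyridine-bearing ethyl((pyridin-4-yl)methyl)amino and its hydrogen-bond acceptor for 4-methylpiperidin-1-yl gives a number 3.3 percentage points lower from compound 3 to compound 4 (within the scatter), so at this concentration neither the aromatic ring nor the acceptor is required at this position. No evidence is at hand on what underlies this flat read-out.

Open, on these data alone, is how a carboxylic acid or a longer chain on the piperidine ring would read here. Also open, as far as these compounds go, is which part of the group on the thiocarbonyl carbon of compound 1 goes with its 17.2%.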